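The source may report more compounds than this note shows. Statements on the series, on what has been measured and on what is new or still open speak of the compounds shown alone.

Measured compounds in a functional assay on PC-3 cells (Homo sapiens) for inhibition, read by MTT assay, with a stated time of 48 h; on this read-out lower numbers stand for stronger inhibition and higher numbers for weaker inhibition:
compound 1 `COc1ccc(-n2c(S)nnc2-c2cc(OC)c(OC)c(OC)c2)cc1` gives > 60000 nM; this is a limit of the assay, not a number.
compound 2 `COc1ccc(-n2c(SCC(=O)C3CC3)nnc2-c2cc(OC)c(OC)c(OC)c2)cc1` gives 37200 nM.
compound 3 `COc1cc(-c2nnc(S)n2-c2ccc(N(C)C)cc2)cc(OC)c1OC` gives > 60000 nM; again a limit of the assay, not a number.

Compound 3 therefore stands at the limit of > 60000 nM in this assay, at which 2 of the 3 values shown sit, and a step that the two limits leave unreadable from compound 1 to compound 3. The unmeasured compound 4 `COc1cc(-c2nnc(SCC(=O)c3ccc(F)cc3)n2-c2ccc(N(C)C)cc2)cc(OC)c1OC` differs from compound 3 by ((4-fluorophenyl)carbonyl)methyl in place of hydrogen on a sulfur. Going by the values given here, the only step of the same kind already seen is an at least 1.6-fold lower number from compound 1 to compound 2 (0.20 log units; that floor lies within the scatter), a move from a limit to a readable number. On that basis a comparable move is expected for compound 4: an at least 2.0-fold lower number from compound 3 to compound 4 (0.30 log units; that floor lies within the scatter). Compound 4 is estimated at 30000 nM in this assay, between 8000 nM and 70000 nM, with a real chance that the assay again reports only a limit.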

Compound 4, half-maximal inhibitory concentration: 42300 nM
Compound 4: the middle estimate sits 1.4-fold (0.15 log units) below what was measured; measured number inside the range.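

In this assay, ((4-fluorophenyl)carbonyl)methyl on the sulfur again leads from a limit to a readable number: an at least 1.4-fold lower number from compound 3 to compound 4 (0.15 log units; that floor lies within the scatter). The move at this sulfur therefore appears with both the methoxy and the dimethylamino compounds, though only as a floor in each case. Compound 3 remains a limit, so the true size of the step cannot be read: the limit of > 60000 nM in this assay, at which 2 of the 4 values shown sit.

The two sulfur substituents sit on different cores, so they cannot be ranked against each other. As far as these compounds go, whether a sulfur chain ending in a carboxylic acid or an amine would give a stronger reading stays open.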